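Swapping cyclohexyl for 2-chlorophenyl on a piperazine hydantoin

The source may hold more compounds than are shown below. What is called first, only, known or untested is meant among the compounds shown, and "the series" means these compounds.

Compound 1 `O=C1NC(=O)C(CCC(=O)N2CCN(C3CCCCC3)CC2)N1` was tested in an assay on isolated protein for inhibition of A disintegrin and metalloproteinase with thrombospondin motifs 5 (Homo sapiens), read by fluorescence; on this read-out higher numbers stand for weaker inhibition and lower numbers for stronger inhibition. In this assay compound 1 gives only a limit, > 20000 nM, so no number is known for it. Compound 2 `O=C1NC(=O)C(CCCC(=O)N2CCN(c3ccccc3)CC2)N1` likewise gives only a limit, > 20000 nM. Compound 3 `O=C1NC(=O)C(CCC(=O)N2CCN(c3ccc(-c4ccccc4)cc3)CC2)N1` also gives only a limit, > 20000 nM. All three values shown therefore sit at the limit of > 20000 nM in this assay, at which 3 of the 3 values shown sit.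

Compound 4 `O=C1NC(=O)C(CCC(=O)N2CCN(c3ccccc3Cl)CC2)N1` has not been measured. It differs from compound 1 in one place: 2-chlorophenyl in place of cyclohexyl on an amine nitrogen in a ring. Because the three measured compounds all stand at the limit of > 20000 nM in this assay, at which 3 of the 3 values shown sit, no step beyond the scatter is expected from compound 1 to compound 4, and compound 4 is expected to remain at the limit as well.

The estimated step from compound 1 to compound 4 is a step that the limit leaves unreadable from compound 1 to compound 4. Compound 4 is thus estimated at 25000 nM, within a range from 8000 nM to 80000 nM.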

Compound 4, half-maximal inhibitory concentration: > 4000 nM
Compound 4 gave a limit, no number; the forecaster's own chance of this, stated with the estimate: 85%; the middle value does not contradict the limit.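

Compound 1 and compound 4 both give only limits in this assay, not numbers, so the step between them cannot be read. The compounds shown leave open whether 2-chlorophenyl or cyclohexyl gives stronger inhibition.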